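This account rests on a few compounds, and the source may have more. Where it says the series, first, only, none or still open, it means among the compounds named here.

Compound 1 `CCCCCCCCCc1cc2cn(COCCO)c(O)nc-2n1` is known in a functional assay on HEL cells (Homo sapiens), read by microscopy (on this read-out lower numbers stand for higher toxicity in this test and higher numbers for lower toxicity in this test), only through a limit of the measurement, not a number: compound 1 gives > 80000 nM (the limit of > 80000 nM in this assay, at which 1 of the 3 values shown sits). Compound 2 `CCCCCCCCc1cc2cn(COCCO)c(=O)nc2o1` also stops at a limit, reported as >= 80000 nM (the limit of >= 80000 nM in this assay, at which 1 of the 3 values shown sits). Compound 3 `CCCCc1cc2cn(COCCO)c(=O)nc2o1` likewise sits at a limit, given as > 400000 nM (the limit of > 400000 nM in this assay, at which 1 of the 3 values shown sits). The step that the two limits leave unreadable from compound 2 to compound 3 therefore cannot be read. Compound 4 `CCCCCCCCCCCc1cc2cn(COCCO)c(O)nc-2n1` differs from compound 1 by ethyl in place of hydrogen on a saturated chain carbon, nine bonds along the chain from an aromatic carbon. For the measured compounds named here, no measured step bears readably on this change, since all three values shown are limits. Compound 4 is thus expected to remain at a limit too, and the step of a number no higher from compound 1 to compound 4 (the limit leaves the size open) is expected to be small. Compound 4 is estimated at 80000 nM, between 40000 nM and 400000 nM, most likely reported only as a limit.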

Compound 4, minimum cytotoxic concentration: 80000 nM
For compound 4 middle estimate and measured number coincide at the digits printed; measured number inside the range.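

In this assay, for the compounds shown here, compound 4 gives a plain number, 80000 nM, the first value here that is not a limit. Compound 1 stands only at a limit: the limit of > 80000 nM in this assay, at which 1 of the 4 values shown sits. Ethyl in place of hydrogen, nine bonds along the chain from an aromatic carbon, thus gives a number no higher from compound 1 to compound 4 (the limit leaves the size open), so this change has a direction but no readable size. The compounds shown leave open whether a still longer chain would give a lower number. They also leave open what an amine in place of the ethyl would give at this position.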